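The source may hold more compounds than are shown below. What is called first, only, known or untested is meant among the compounds shown, and "the series" means these compounds.

Measured compounds:
compound 1, `C[C@H](CC(=O)NC(=N)NCCCc1c[nH]cn1)c1ccccc1`: 93%
compound 2, `Cc1nc(N)sc1CCCNC(=N)NC(=O)C[C@H](C)c1ccccc1`: 87%

In a functional assay on cardiac atrium for agonist activity at histamine H2 receptor (Cavia porcellus) (on this read-out lower numbers stand for smaller maximal responses and higher numbers for larger maximal responses), compound 2 gives 87%, the lowest of the two numbers measured; compound 1 gives 93%, which lies within the scatter of it. Compound 3 is `C[C@@H](CC(=O)NC(=N)NCCCc1c[nH]cn1)c1ccccc1`. It differs from compound 2 by the change (1H-imidazol-4-yl in place of 2-amino-4-methyl-1,3-thiazol-5-yl on a saturated chain carbon, three bonds along the chain from an amine nitrogen). Going by the values given here, no step between measured compounds covers this change. With both measured values lying so close, the maximal response of compound 3 is expected to sit in the same region, a number 3 percentage points higher from compound 2 to compound 3 (within the scatter) being a step not beyond the scatter. Compound 3 is estimated at 90%, with a range from 78% to 100%.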

Compound 3, largest response reached (Emax), in percent of the reference or control that the assay uses: 102%
Compound 3: the middle estimate sits 12 percentage points below what was measured; measured number outside the range, above it.
By their numbers in this assay, from the lowest: compounds 2, 1 and 3 (each within the scatter of the next, the first and the last beyond it).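

In this assay, the ring on the saturated chain carbon proves to matter: 1H-imidazol-4-yl in place of 2-amino-4-methyl-1,3-thiazol-5-yl gives a number 15 percentage points higher from compound 2 to compound 3 (beyond the scatter). Reversing the drawn configuration at the stereocentre on the saturated chain carbon gives a number 9 percentage points higher from compound 1 to compound 3 (within the scatter), so the maximal response does not separate these two forms. This comparison carries one caveat: the fact that one of compounds 1 and 3 is drawn with a defined configuration and the other without, at the place where they differ

The compounds shown leave open how a methyl group on the 1H-imidazol-4-yl ring or a longer chain would read. They also leave open whether the stereocentre matters with 2-amino-4-methyl-1,3-thiazol-5-yl in place.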